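This account rests on a few compounds, and the source may have more. Where it says the series, first, only, none or still open, it means among the compounds named here.

Measured compounds in a functional assay on OCI-Ly3 cells (Homo sapiens) for antiproliferative activity; a lower number here means that less compound is needed, a higher number that more compound is needed for the effect:

compound 1 `O=C(Nc1cnc(-n2nccn2)c(Cl)c1)Nc1cnc2cc(F)ccc2c1C1CC1`, 900 nM
compound 2 `O=C(Nc1cnc(-n2nccn2)c(Cl)c1)Nc1cnc2ccc(F)cc2c1C1CC1`, 720 nM
compound 3 `COc1ccc2c(C3CC3)c(NC(=O)Nc3cnc(-n4nccn4)c(Cl)c3)cnc2c1`, a limit, > 20000 nM

Compound 1 and compound 2 share all atoms joined differently; the difference between the two cores is not broken down here. In this assay compound 1 and compound 2 sit within the scatter of each other. For compound 3 the result is only a limit, (the limit of > 20000 nM in this assay, at which 1 of the 3 values shown sits). The change from compound 1 to compound 3 is methoxy in place of fluoro on an aromatic carbon, and the step is an at least 22-fold higher number from compound 1 to compound 3 (1.34 log units; beyond the scatter).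

Compound 4 `COc1ccc2ncc(NC(=O)Nc3cnc(-n4nccn4)c(Cl)c3)c(C3CC3)c2c1` is not yet measured. It differs from compound 2 by methoxy in place of fluoro on an aromatic carbon, the same change, at the same kind of place, as from compound 1 to compound 3. The step is expected to be a 28-fold higher number from compound 2 to compound 4 (1.44 log units; beyond the scatter), resting on compound 1 and compound 3, where the step was an at least 22-fold higher number from compound 1 to compound 3 (1.34 log units; beyond the scatter). For compound 4 the estimate in this assay is 20000 nM, between 7000 nM and 60000 nM.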

Compound 4, half-maximal effective concentration: 2390 nM
The estimate for compound 4 lay 8.4-fold (0.92 log units) above the measured number; the whole stated range lies above it.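

In this assay the new step is a 3.3-fold higher number from compound 2 to compound 4 (0.52 log units; beyond the scatter), so methoxy in place of fluoro on an aromatic carbon moves the number the same way on both cores. The size of the step does not carry from one core to the other: the same change on two cores in this assay, an at least 22-fold higher number (1.34 log units; beyond the scatter) from compound 1 to compound 3 and a 3.3-fold higher number (0.52 log units; beyond the scatter) from compound 2 to compound 4, at least 6.6-fold (0.82 log units) apart, beyond the scatter of two such steps. Going by these compounds, compound 3 is held only as a limit, and two cores set no rule for a third, so the full size of that step stays unknown: the limit of > 20000 nM in this assay, at which 1 of the 4 values shown sits.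

Still open, on these data alone, is whether another group in the same place, such as an amine or a nitrile, would also give steps that differ between these two cores. The compounds shown also give no reason for the gap between the two steps.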